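A weak series: trimming the amine to an alcohol

This account rests on a few compounds, and the source may have more. Where it says the series, first, only, none or still open, it means among the compounds named here.

In a functional assay on SW-620 cells (Homo sapiens) for inhibition, read by MTT assay, with a stated time of 72 h (a lower number here means a stronger inhibitor, a higher number a weaker inhibitor), three compounds of a shared core have been measured. Compound 1, `COc1cc(Oc2cccc(Nc3ccccc3)c2)cc(OC)c1CNC1CC1`, reaches only the limit of the assay, > 20000 nM. Compound 2, `COc1cc(Oc2cccc(Nc3ccccc3)c2)cc(OC)c1CNCCNC(C)=O`, gives 11900 nM, which is the highest of the two numbers recorded. Compound 3, `COc1ccc([C@@H](C)NCc2c(OC)cc(Oc3cccc(Nc4ccccc4)c3)c(OC)c2OC)cc1`, gives 8250 nM, and its value and that of compound 2 lie within the scatter of each other. For the measured compounds named here, the one measured step, an at least 1.6-fold lower number from compound 1 to compound 2 (0.22 log units; that floor lies within the scatter), is set against a limit, (the limit of > 20000 nM in this assay, at which 1 of the 3 values shown sits), so its floor tells little.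

Compound 4, `COc1cc(Oc2cccc(Nc3ccccc3)c2)cc(OC)c1CCO`, differs from compound 2 by hydroxymethyl in place of (2-acetamidoethyl)amino on a saturated chain carbon bound to an aromatic carbon. Going by the values given here, no measured step alters this part of the molecule in the same way: the step from compound 1 to compound 2 exchanges one substituent on the amine nitrogen for another, whereas here the amine itself leaves and a hydroxymethyl group enters. Among the compounds with values here, since every measured value in this assay is weak and the only step lies within the scatter, compound 4 is expected to remain weak, with a 1.5-fold higher number from compound 2 to compound 4 (0.18 log units; within the scatter) likely no larger than the scatter and possibly toward a limit. Compound 4 is estimated at 18000 nM, within 7000 nM to 50000 nM.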

Compound 4, half-maximal inhibitory concentration: > 20000 nM
Compound 4 ended at the assay's limit (the forecaster's own chance of this, stated with the estimate: 45%); at least 1.1-fold (0.04 log units) between middle value and limit.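

For the compounds shown here, compound 4 takes the change further than the earlier compounds did: the step between compound 1 and compound 2 only exchanged one substituent on the amine nitrogen, whereas here the amine itself is gone from the saturated chain carbon bound to an aromatic carbon. In this assay compound 4 gives > 20000 nM, which is a limit of the assay and not a number. With hydroxymethyl in place of (2-acetamidoethyl)amino, the result is an at least 1.6-fold higher number from compound 2 to compound 4 (0.22 log units; that floor lies within the scatter), so trimming the chain to an alcohol brings no gain in this weak series, though the real size of the loss stays unknown, and the step between compound 1 and compound 4 cannot be read because both compounds sit at a limit: the limit of > 20000 nM in this assay, at which 2 of the 4 values shown sit.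

Going by these compounds, how far compound 1 and compound 4 lie beyond that limit remains open, and so does whether the amine nitrogen contributes anything to the weak inhibition seen with compound 2. Also open, on these data alone, is how a carboxylic acid, a primary amine or a longer chain ending in a hydroxyl group would read at this place on the shared core.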